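A Trifluoromethyl Group Enters Where Methyl Cost Potency

This account rests on a few compounds, and the source may have more. Where it says the series, first, only, none or still open, it means among the compounds named here.

Of the compounds shown here, three sharing one core have been measured in a functional assay on HCT-116 cells (Homo sapiens) for antiproliferative activity, read by MTT assay, with a stated time of 72 h; on this read-out lower numbers stand for stronger inhibition and higher numbers for weaker inhibition. Compound 1 `C/C(C#Cc1ccccc1)=N\N/C(N)=N/S(=O)(=O)c1cc(C)c(Cl)cc1SCc1ccccc1` gives 10000 nM. Compound 2 `C/C(C#Cc1ccccc1)=N\N/C(N)=N/S(=O)(=O)c1cc(C)c(Cl)cc1SCc1cccc(C)c1` gives 160000 nM. Compound 3 `Cc1cc(S(=O)(=O)/N=C(\N)N/N=C/C#Cc2ccccc2)c(SCc2ccccc2C(F)(F)F)cc1Cl` gives 18000 nM. Compound 1 therefore sits at the low end of the three numbers, with compound 3 close enough to fall within the usual scatter of repeated measurements, while compound 2 lies far beyond it.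

The new compound 4 `C/C(C#Cc1ccccc1)=N\N/C(N)=N/S(=O)(=O)c1cc(C)c(Cl)cc1SCc1cccc(C(F)(F)F)c1` differs from compound 1 in one place: trifluoromethyl in place of hydrogen on an aromatic carbon. Within the data shown here, only one measured step bears directly on this change, the addition of methyl at the same kind of position, which gave a 16-fold higher number from compound 1 to compound 2 (1.20 log units; beyond the scatter). Compound 3 carries its trifluoromethyl elsewhere on that ring and also differs in the hydrazone, so its value offers no clean comparison. Given the large loss seen for compound 2, a weakening step is expected here as well, though its exact size is uncertain.

Compound 4 is therefore estimated at 60000 nM, within 15000 nM to 200000 nM, an expected step of a 6.0-fold higher number from compound 1 to compound 4 (0.78 log units; beyond the scatter).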

Compound 4, half-maximal inhibitory concentration: 14000 nM
Estimate against measurement, compound 4: 4.3-fold (0.63 log units) above; measured number outside the range, below it.
By their numbers in this assay, from the lowest: compounds 1, 4 and 3 (each within the scatter of the next); then compound 2.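

In this assay, placing trifluoromethyl on this aromatic carbon of the benzyl ring leaves the number within the usual scatter (a 1.4-fold higher number from compound 1 to compound 4 (0.15 log units; within the scatter)). The position therefore accepts at least one substituent without a measurable loss, so the sharp rise seen with methyl (a 16-fold higher number from compound 1 to compound 2 (1.20 log units; beyond the scatter)) does not apply to every group placed there, and exchanging methyl for trifluoromethyl recovers nearly all of that loss (an 11-fold lower number from compound 2 to compound 4 (1.06 log units; beyond the scatter)). Nothing shown explains why these two groups behave so differently.

On these data alone, with only hydrogen, methyl and trifluoromethyl compared here, it remains open how a methoxy group, an amine or a carboxylic acid would behave on this carbon. Compound 3 differs from compound 4 in more than one place, so the effect of moving trifluoromethyl around this ring also remains unresolved.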